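A few compounds are considered here, and "the series" means these few. Any claim that something is new, unique, unknown or untested is made for them only; others in the source may bear on it.

Measured compounds: compound 1, `CCSC[C@H](NC(C)=O)C(=O)CCl`, gives 52800 nM in a functional assay on NALM-6 cells (Homo sapiens); a higher number here means a weaker inhibitor, a lower number a stronger inhibitor; compound 2, `CCCSC[C@H](NC(C)=O)C(=O)CCl`, gives 6900 nM; compound 3, `CCCCCCCCCSC[C@H](NC(C)=O)C(=O)CCl`, gives 7300 nM.

The change from compound 1 to compound 2 is methyl in place of hydrogen on a saturated chain carbon, two bonds along the chain from a sulfur, and it made the step of a 7.7-fold lower number from compound 1 to compound 2 (0.88 log units; beyond the scatter). The difference between the core of compound 1 and the core of compound 3 is not broken down here. From compound 2 to compound 3 the step is a 1.1-fold higher number from compound 2 to compound 3 (0.02 log units; within the scatter), so the two values show no meaningful separation.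

Compound 4, `CCCCCCCCCCSC[C@H](NC(C)=O)C(=O)CCl`, is not yet measured. It differs from compound 3 by methyl in place of hydrogen on a saturated chain carbon, nine bonds along the chain from a sulfur. This is the same kind of change as that from compound 1 to compound 2, but the place differs: there the methyl enters two bonds along the chain from a sulfur, here nine bonds along the chain from a sulfur. Because the step of a 1.1-fold higher number from compound 2 to compound 3 (0.02 log units; within the scatter) is within the scatter, lengthening the chain further is expected to change little, so the step from compound 3 to compound 4 is estimated to be about a 1.0-fold lower number from compound 3 to compound 4 (0.02 log units; within the scatter) in this assay, much smaller than the earlier one. Compound 4 is therefore expected to give about 7000 nM, estimated to fall between 3500 nM and 14000 nM.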

Compound 4, half-maximal inhibitory concentration: 4700 nM
Estimate against measurement, compound 4: 1.5-fold (0.17 log units) above; the range from low to high includes it.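

In this assay, methyl in place of hydrogen nine bonds along the chain from a sulfur gives a 1.6-fold lower number from compound 3 to compound 4 (0.19 log units; within the scatter), and the longer comparison gives a 1.5-fold lower number from compound 2 to compound 4 (0.17 log units; within the scatter), so neither step separates its two compounds beyond ordinary measurement noise. The same swap of hydrogen for methyl therefore did not carry over at the same size from one core to the other: the same change on two cores in this assay, a 7.7-fold lower number (0.88 log units; beyond the scatter) from compound 1 to compound 2 and a 1.6-fold lower number (0.19 log units; within the scatter) from compound 3 to compound 4, 4.9-fold (0.69 log units) apart, beyond the scatter of two such steps This shows that the size of the step in this series depends on where it is made, with a clear gain on the short chain of compound 1 and no clear change on the long chain of compound 3, but two examples give no rule and do not explain the difference.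

The compounds shown leave open whether a chain longer than that of compound 4 would stay at this level. They also leave open how a chain carrying an amine or a carboxylic acid would behave.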